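A Longer Amine Chain on the Shared Core

The source may hold more compounds than are shown below. What is called first, only, known or untested is meant among the compounds shown, and "the series" means these compounds.

Compound 1 `CC(C)N(Cc1ccccc1)C(=O)Nc1ccc(-c2cn[nH]c2)cc1` gives 8 nM in an assay on isolated protein for inhibition of Rho-associated protein kinase 2 (Homo sapiens), read by HTRF, with a stated time of 4 h; on this read-out higher numbers stand for weaker inhibition and lower numbers for stronger inhibition.
Compound 2 `Nc1cccc(CNC(=O)Nc2ccc(-c3cn[nH]c3)cc2)c1` gives 3 nM; 3 nM (2 entries) in this assay.
Compound 3 `COc1cccc(CNC(=O)Nc2ccc(-c3cn[nH]c3)cc2N(C)C)c1` is recorded as < 1 nM in this assay.

Compound 1 and compound 2 each have a measured number. For compound 3 there is no number but only a limit of the assay, and that is where compound 3 stands: the limit of < 1 nM in this assay, at which 1 of the 3 values shown sits. Among the measured compounds shown here, no pair of these three compounds differs in a single place, so no measured step is available to lean on.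

Compound 4 `COc1cccc(CNC(=O)Nc2ccc(-c3cn[nH]c3)cc2N(C)CCN(C)C)c1` has not been measured. It differs from compound 3 by (dimethylamino)methyl in place of hydrogen on a saturated chain carbon bound to a nitrogen on an aromatic ring. With compound 3 already sitting at a limit, a further gain could not be seen, and the change is expected to leave the result within the usual scatter, so the expected step is a number no lower from compound 3 to compound 4 (the limit leaves the size open). Compound 4 is therefore expected to come out at about 1 nM, with a range from 0.3 nM to 5 nM, and it may well again be reported only as a limit.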

Compound 4, half-maximal inhibitory concentration: < 1 nM
Compound 4 ended at the assay's limit (the forecaster's own chance of this, stated with the estimate: 45%); the middle value lies on the limit itself.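

Compound 3 and compound 4 both sit at a limit of this assay rather than at a number, so no step can be read from one to the other: the limit of < 1 nM in this assay, at which 2 of the 4 values shown sit.

The compounds shown leave open whether the 2-(dimethylamino)ethyl chain of compound 4 changes the inhibition at all.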